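This account rests on a few compounds, and the source may have more. Where it says the series, first, only, none or still open, it means among the compounds named here.

Working notes on the series: in a functional assay on Caco-2 cells (Homo sapiens) for antiproliferative activity, read by MTT assay, with a stated time of 48 h (a higher number here means a weaker inhibitor, a lower number a stronger inhibitor), compound 1 (`CCOC(=O)C(CC(=O)OC)NC(=O)c1ccc(C(CC)(CC)c2ccc(OCCC(O)(CC)CC)c(C)c2)n1CC`) gives 3020 nM and compound 2 (`CCn1c(C(=O)NC(C)C(=O)O)ccc1C(CC)(CC)c1ccc(OCCC(O)(CC)CC)c(C)c1`) gives 46500 nM, so compound 2 holds the higher of the two numbers so far. Compound 3 (`CCC(C)C(CO)NC(=O)c1ccc(C(CC)(CC)c2ccc(OCCC(O)(CC)CC)c(C)c2)n1CC`) differs from compound 2 on an amide-type nitrogen, with 1-(hydroxymethyl)-2-methylbutyl in place of 1-carboxyethyl on an amide-type nitrogen. Going by the values given here, only one measured step bears on this change, at the same place: a 15-fold higher number from compound 1 to compound 2 (1.19 log units; beyond the scatter), a large step beyond the scatter. Compound 1 also lacks 1-carboxyethyl and stands at 3020 nM, so a large step to a lower number is expected in this assay. Among the compounds with values here, this rests on a single step, and the group entering compound 3 is not the one carried by compound 1. The estimated step is a 7.8-fold lower number from compound 2 to compound 3 (0.89 log units; beyond the scatter). For compound 3 the estimated value is 6000 nM, with an expected range of 1800 nM to 20000 nM.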

Compound 3, half-maximal inhibitory concentration: > 50000 nM
Compound 3: only a limit was reported; the forecaster's own chance of this, stated with the estimate: 5%; middle value at least 8.3-fold (0.92 log units) away from the limit.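

For compound 3 the reading is a limit and not a number: the limit of > 50000 nM in this assay, at which 1 of the 3 values shown sits.

At this amide-type nitrogen, the absence of 1-carboxyethyl does not by itself bring a number near that of compound 1, as 1-(hydroxymethyl)-2-methylbutyl gives an at least 16-fold higher number from compound 1 to compound 3 (1.21 log units; beyond the scatter). Going by these compounds alone, the comparison with the carboxylic acid reads an at least 1.0-fold higher number from compound 2 to compound 3 (0.03 log units; that floor lies within the scatter), a floor that establishes no order for that pair.

Open, going by these compounds, is how much of the standing of compound 1 rests on the particular group it carries at this nitrogen, as its group differs from that of compound 3 in more than one feature. Also open, on these data alone, is whether a methyl ester of 1-carboxyethyl, a plain 2-hydroxyethyl group or a primary amine on a short chain at this nitrogen would give a measurable number in this assay.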